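Swapping a benzyl for a benzoyl on the ring nitrogen

The source may report more compounds than this note shows. Statements on the series, on what has been measured and on what is new or still open speak of the compounds shown alone.

Compound 1 `Fc1ccc(C(SCCNC2CCN(Cc3ccccc3)CC2)c2ccc(F)cc2)cc1` gives 3.81 nM in an assay on membranes from Cortex for displacement of a labelled ligand from Sigma non-opioid intracellular receptor 1 (Cavia porcellus), read by scintillation counting, with a stated time of 120 min; on this read-out lower numbers stand for stronger inhibition and higher numbers for weaker inhibition. Compound 2 `Fc1ccc(C(SCCNC2CCN(Cc3ccc(Cl)cc3)CC2)c2ccc(F)cc2)cc1` gives 45.5 nM, and compound 3 `O=C(c1ccc(F)cc1)N1CCC(NCC[S+]([O-])C(c2ccc(F)cc2)c2ccc(F)cc2)CC1` gives 1440 nM. Compound 2 thus stands second highest of the three numbers, closest to compound 1 and farthest from compound 3. For the measured compounds named here, the step of a 12-fold higher number from compound 1 to compound 2 (1.08 log units; beyond the scatter) is the only measured step that differs in one place, and it changes a different part of the molecule from the change now in question. Compound 4 `O=C(c1ccc(F)cc1F)N1CCC(NCCSC(c2ccc(F)cc2)c2ccc(F)cc2)CC1` differs from compound 2 in this way: (2,4-difluorophenyl)carbonyl in place of 4-chlorobenzyl on an amine nitrogen in a ring. Going by the values given here, no measured step covers this exact change; compound 3 carries a carbonyl group on the same ring nitrogen yet also differs elsewhere, so its value is only a rough pointer. Given that compound 3 sits well above compound 2 in this assay, compound 4 is expected to show a higher number than compound 2, an estimated step of a 6.6-fold higher number from compound 2 to compound 4 (0.82 log units; beyond the scatter). Compound 4 is estimated at 300 nM, with a likely range from 60 nM to 1500 nM.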

Compound 4, inhibition constant: 20.6 nM
Compound 4: middle estimate off by 15-fold (1.16 log units), on the high side; the whole stated range lies above it.
By their numbers in this assay, from the lowest: compound 1; then compound 4; then compound 2; then compound 3.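

In this assay the ring nitrogen still gives a low number when it carries a carbonyl-linked group: (2,4-difluorophenyl)carbonyl in place of 4-chlorobenzyl brings a 2.2-fold lower number from compound 2 to compound 4 (0.34 log units; beyond the scatter) and so a benzyl-type group is not required at this position. Set against the plain benzyl, the same group brings a 5.4-fold higher number from compound 1 to compound 4 (0.73 log units; beyond the scatter) and so compound 1 keeps the lowest number of the four. Nothing measured here gives a reason for either step.

The entering group differs from both benzyl groups in its carbonyl link and in its two fluorines at once, so the compounds shown leave open which of these matters. An unsubstituted benzoyl group, or a longer chain linking the ring nitrogen to the aromatic ring, would help to separate the two.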